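Methyl for fluoro, carried over to compound 4

This account rests on a few compounds, and the source may have more. Where it says the series, first, only, none or still open, it means among the compounds named here.

Measured in a functional assay on thoracic aorta (strain Wistar) with Aorta (Rattus norvegicus) as the target, with a stated time of 2 h (on this read-out lower numbers stand for stronger inhibition and higher numbers for weaker inhibition), so far:
compound 1 `CCOC(=O)c1c(-c2ccc(F)cc2)cc(-c2ccccc2)nc1Nc1ccc(Cl)cc1` gives 715000 nM
compound 2 `CCOC(=O)c1c(-c2ccc(C)cc2)cc(-c2ccccc2)nc1Nc1ccc(Cl)cc1` gives 266000 nM
compound 3 `CCOC(=O)c1c(-c2ccc(F)cc2)cc(-c2ccccc2)nc1N` gives 335000 nM

Compound 4 `CCOC(=O)c1c(-c2ccc(C)cc2)cc(-c2ccccc2)nc1N` has not been measured. Compound 1 and compound 2 differ by methyl in place of fluoro on an aromatic carbon, and this gave a 2.7-fold lower number from compound 1 to compound 2 (0.43 log units; beyond the scatter). The cores of compound 1 and compound 3 differ by hydrogen in place of 4-chlorophenyl on a nitrogen on an aromatic ring, with a 2.1-fold lower number from compound 1 to compound 3 (0.33 log units; beyond the scatter). Compound 4 stands to compound 3 as compound 2 stands to compound 1, by methyl in place of fluoro on an aromatic carbon, at a place described in the same words, so it is the same change. Compound 2 and compound 3 lie within the scatter of each other, so no order is drawn between them. In this assay, within the data shown here, compound 4 is expected to show a 2.6-fold lower number from compound 3 to compound 4 (0.41 log units; beyond the scatter), close to the earlier step, because a 2.7-fold lower number from compound 1 to compound 2 (0.43 log units; beyond the scatter) is the only measured instance of this change. The estimate for compound 4 is 130000 nM, expected between 60000 nM and 300000 nM.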

Compound 4, half-maximal inhibitory concentration: 327000 nM
For compound 4 the middle estimate is 2.5-fold (0.40 log units) below the measured one, and the stated range ends below it.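

In this assay, methyl in place of fluoro gives a 1.0-fold lower number from compound 3 to compound 4 (0.01 log units; within the scatter), and this step cannot be separated from the one on the core of compound 1: the same change on two cores in this assay, a 2.7-fold lower number (0.43 log units; beyond the scatter) from compound 1 to compound 2 and a 1.0-fold lower number (0.01 log units; within the scatter) from compound 3 to compound 4, 2.6-fold (0.42 log units) apart, within the scatter of two such steps. Hydrogen in place of 4-chlorophenyl on the nitrogen gives a 1.2-fold higher number from compound 2 to compound 4 (0.09 log units; within the scatter), and this step likewise cannot be separated from its earlier counterpart: the same change on two cores in this assay, a 2.1-fold lower number (0.33 log units; beyond the scatter) from compound 1 to compound 3 and a 1.2-fold higher number (0.09 log units; within the scatter) from compound 2 to compound 4, 2.6-fold (0.42 log units) apart, within the scatter of two such steps. Among these compounds, the data therefore show neither that either change carries over at its earlier size nor that its size depends on the core, and each comparison rests on only one pair of steps.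

As far as these compounds go, the effect of replacing fluoro with chloro, methoxy or an amine remains open. So does the effect of a carboxylic acid or amide in place of the ethyl ester, or of a longer alkyl chain on the nitrogen.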